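Swapping a Chlorophenyl for a Nitrophenyl: Expected Cytotoxicity

The compounds below may be only part of what the source reports. "The series", "measured", "known", "first", "only" and "open" are said of these compounds alone.

Compound 1, `CC1=C(C(=O)Nc2ccccc2Cl)C(c2ccccc2Cl)NC(=O)N1`: "non-toxic" (no number reported)
Compound 2, `CC1=C(C(=O)Nc2ccccc2Cl)C(c2ccc(Br)cc2)NC(=O)N1`: > 100000 nM

In an ADME assay on Vero cells (Chlorocebus sabaeus) for cytotoxicity, read by XTT assay, with a stated time of 72 h (on this read-out higher numbers stand for lower toxicity in this test and lower numbers for higher toxicity in this test), compound 1 is recorded as "non-toxic" (no number reported), with no number attached. Compound 2 reaches only a limit of this assay, > 100000 nM. Both measured compounds thus sit at the gentle end of the scale, at the limit of > 100000 nM in this assay, at which 1 of the 2 values shown sits. Compound 3, `CC1=C(C(=O)Nc2ccccc2Cl)C(c2cccc([N+](=O)[O-])c2)NC(=O)N1`, differs from compound 1 by 3-nitrophenyl in place of 2-chlorophenyl on a saturated ring carbon. Among the measured compounds shown here, no measured step shows what this change does in this assay, so no shift beyond the usual scatter is expected. Compound 3 is therefore estimated to give about 100000 nM in this assay, within a range from 30000 nM to 300000 nM.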

Compound 3, half-maximal cytotoxic concentration: "non-toxic" (no number reported)
Compound 3: no number reported, and the estimate cannot be compared.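

In this assay, among the compounds shown here, compound 1 gives "non-toxic" (no number reported) and compound 3 gives "non-toxic" (no number reported), so no step between them can be read. Going by these compounds, whether 3-nitrophenyl in place of 2-chlorophenyl shifts cytotoxicity at all stays open.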